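Chain extension at the amine of the shared core

The source may hold more compounds than are shown below. What is called first, only, known or untested is meant among the compounds shown, and "the series" means these compounds.

Working notes on the series. Compound 1 `CCCCNc1nc(SCCCC)nc2ncccc12` carries a butyl chain on the amine and a butylthio group; in a functional assay on T-24 cells (Homo sapiens) for cytotoxicity, read by neutral red uptake, with a stated time of 72 h (a lower number here means a stronger inhibitor, a higher number a weaker inhibitor), compound 1 gives 10600 nM. Compound 2 `CCCCCNc1nc(SCCCC)nc2ncccc12` is the next homologue, and in this assay compound 2 gives 8900 nM. On the two numbers available compound 2 stands alongside compound 1, the step of a 1.2-fold lower number from compound 1 to compound 2 (0.08 log units; within the scatter) lying within the scatter. Compound 3 `CCCCCCNc1nc(SCCCC)nc2ncccc12` continues the same direction: methyl in place of hydrogen on a saturated chain carbon, five bonds along the chain from a nitrogen on an aromatic ring. Among the measured compounds shown here, the only measured step that bears on it is a 1.2-fold lower number from compound 1 to compound 2 (0.08 log units; within the scatter), and since it stayed within the scatter, a further homologation of the same kind gives no ground to expect a step beyond the scatter in this assay, in either direction. For compound 3 the expected step is a 1.1-fold lower number from compound 2 to compound 3 (0.05 log units; within the scatter). The estimate for compound 3 in this assay is 8000 nM, with a range from 4000 nM to 16000 nM.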

Compound 3, half-maximal inhibitory concentration: 4500 nM
Compound 3: the middle estimate sits 1.8-fold (0.25 log units) above what was measured, within the range that was stated.
By their numbers in this assay, from the lowest: compounds 3, 2 and 1 (each within the scatter of the next, the first and the last beyond it).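

In this assay the added methyl, five bonds along the chain from a nitrogen on an aromatic ring, gives a 2.0-fold lower number from compound 2 to compound 3 (0.30 log units; within the scatter) and so stays within the scatter on its own, as did the step before it. Ethyl in place of hydrogen, four bonds along the chain from that nitrogen, gives a 2.4-fold lower number from compound 1 to compound 3 (0.37 log units; beyond the scatter) and is the first comparison in the series to pass beyond the scatter, showing that this position tolerates the longer chain and that a modest difference appears only across the hexyl and butyl compounds. No measurement shown accounts for this difference.

From the compounds shown here alone, whether a longer chain such as heptyl or octyl would extend this direction remains open. So does the outcome with a terminal amine or carboxylic acid on the chain.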